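This account rests on a few compounds, and the source may have more. Where it says the series, first, only, none or still open, it means among the compounds named here.

Compound 2 `O=C(NC(=S)N1CCc2c(OCCCCCOc3ccc(Cl)cc3)cccc21)C1CCCC1` sits at the edge of what an ADME assay on Huh-7 cells (Homo sapiens) for cytotoxicity (on this read-out lower numbers stand for higher toxicity in this test and higher numbers for lower toxicity in this test), resolves: in this assay compound 2 gives > 50000 nM, a limit rather than a number (the limit of > 50000 nM in this assay, at which 1 of the 2 values shown sits). Among the measured compounds shown here, its neighbour compound 1 `O=C(NC(=S)N1CCc2c(OCCCCCOc3ccc(Cl)cc3)cccc21)c1cccc([N+](=O)[O-])c1` gives 12100 nM in this assay, and the single measured step, an at least 4.1-fold higher number from compound 1 to compound 2 (0.61 log units; beyond the scatter), followed cyclopentyl replacing 3-nitrophenyl. Compound 3 `O=C(NC(=S)N1CCc2c(OCCCCCOc3ccc(Cl)cc3)cccc21)c1ccc2ccccc2c1` reverses that direction with naphthalen-2-yl in place of cyclopentyl on a carbonyl carbon. For the measured compounds named here, since the only comparable step moved from an aryl group to cyclopentyl and lowered toxicity, an aryl returning is expected to move compound 3 back toward compound 1, an estimated step of an at least 3.3-fold lower number from compound 2 to compound 3 (0.52 log units; beyond the scatter), giving compound 3 an expected value of 15000 nM with a range from 5000 nM to 50000 nM.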

Compound 3, half-maximal cytotoxic concentration: > 50000 nM
Compound 3: no number, only a limit; the forecaster's own chance of this, stated with the estimate: 30%; middle value at least 3.3-fold (0.52 log units) away from the limit.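

In this assay compound 3 gives a limit, not a number: the limit of > 50000 nM in this assay, at which 2 of the 3 values shown sit.

The step between compound 2 and compound 3 cannot be read. Naphthalen-2-yl in place of 3-nitrophenyl on a carbonyl carbon still gave an at least 4.1-fold higher number from compound 1 to compound 3 (0.61 log units; beyond the scatter), so an aryl group at this place does not by itself bring the lower number, and of the two aryl compounds only compound 1 shows one.

On these data alone, whether compound 2 and compound 3 differ beyond this limit stays open. So does whether the lower number of compound 1 goes with its nitro group, which a plain phenyl group on the same carbonyl carbon could test.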